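Removing the 3-methoxyphenyl group from compound 2

The source may hold more compounds than are shown below. What is called first, only, known or untested is meant among the compounds shown, and "the series" means these compounds.

For the measured compounds named here, in a functional assay on cells (T-cell line, Homo sapiens) for inhibition (on this read-out lower numbers stand for stronger inhibition and higher numbers for weaker inhibition), compound 2 `COc1cccc(CCCN2CCC(COC(c3ccccc3)c3ccccc3)CC2)c1` gives 1500 nM, the only actual number so far. Compound 1 `COc1ccc(CCCN2CCC(CO)CC2)cc1` reads > 20000 nM, which is a limit of the assay. Compound 3 `CCCN1CCC(COC(c2ccccc2)c2ccccc2)CC1` carries hydrogen in place of 3-methoxyphenyl on a saturated chain carbon, three bonds along the chain from an amine nitrogen in a ring. Going by the values given here, no measured step gauges this change, so compound 2 at 1500 nM is the only anchor. The expected outcome is a weakening beyond the scatter, estimated as a 4.0-fold higher number from compound 2 to compound 3 (0.60 log units; beyond the scatter). Compound 3 is expected at 6000 nM, with an estimated range of 1800 nM to 20000 nM.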

Compound 3, half-maximal inhibitory concentration: 17800 nM
For compound 3 the middle estimate is 3.0-fold (0.47 log units) below the measured one, within the range that was stated.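

In this assay, the 3-methoxyphenyl group at this place carries much of the inhibition of compound 2, with a 12-fold higher number from compound 2 to compound 3 (1.07 log units; beyond the scatter). Inhibition does not vanish without it, as compound 3 still gives a number, 17800 nM. That number lies close to the upper end of the read-out, which limits how far the step can be read: the limit of > 20000 nM in this assay, at which 1 of the 3 values shown sits.

As far as these compounds go, whether the step belongs to the methoxy group or to the aromatic ring stays open, and a plain phenyl at this place would separate the two. Also open, from the compounds shown here alone, is how a pyridyl ring or a shorter chain would read here.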